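Shifting the Methoxy Group: Compound 2 to Compound 3

The source may hold more compounds than are shown below. What is called first, only, known or untested is meant among the compounds shown, and "the series" means these compounds.

Compound 2 `COc1cccc(-c2cn3cc(-c4ccccc4)nc3c(N)n2)c1` carries a 3-methoxyphenyl on the shared core. Among the compounds with values here, in an assay on cells for displacement of a labelled ligand from adenosine receptor A1 (Homo sapiens), read by scintillation counting, with a stated time of 120 min, tested at 1 uM (a higher number here means more inhibition at the concentration tested (going by the name of the read-out), a lower number less inhibition), compound 2 gives 37%, the higher of the two numbers measured so far. Its nearest neighbour is compound 1 `Nc1nccn2cc(-c3ccccc3)nc12`, which lacks that group and in this assay gives 30%; the step of a number 7 percentage points higher from compound 1 to compound 2 (within the scatter) lies within the scatter, so adding the 3-methoxyphenyl made no clear difference.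

Compound 3 `COc1ccc(-c2cn3cc(-c4ccccc4)nc3c(N)n2)cc1` has not yet been measured. It differs from compound 2 in one place: 4-methoxyphenyl in place of 3-methoxyphenyl on an aromatic carbon. The two compounds contain the same atoms, joined differently.

Within the data shown here, only one measured step exists, from compound 1 to compound 2, and it was within the scatter; it tells how a 3-methoxyphenyl compares with hydrogen, not how a 4-methoxyphenyl compares with a 3-methoxyphenyl. Among the measured compounds shown here, no measured step bears directly on moving the methoxy group. The expected step in this assay is a number 2 percentage points lower from compound 2 to compound 3 (within the scatter), which should stay within the scatter with no clear direction. Compound 3 is estimated at 35%, with a range from 15% to 55%.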

Compound 3, a percentage reported as inhibition, at one concentration (the size of the read-out at that concentration, not a potency): 20%
Compound 3: middle estimate off by 15 percentage points, on the high side; the measured number falls inside the stated range.
By their numbers in this assay, from the lowest: compounds 3, 1 and 2 (each within the scatter of the next, the first and the last beyond it).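

In this assay, within the data shown here, the position proves sensitive to where the methoxy group sits on the phenyl ring: with the same atoms joined differently, 4-methoxyphenyl in place of 3-methoxyphenyl gives a number 17 percentage points lower from compound 2 to compound 3 (beyond the scatter) and is the first step here to pass beyond the usual scatter. Against hydrogen at the same aromatic carbon, the 4-methoxyphenyl group gives a number 10 percentage points lower from compound 1 to compound 3 (within the scatter) and so, like the 3-methoxyphenyl group, is not clearly separated from compound 1, which means that the two methoxyphenyl compounds can be told apart only from each other. Nothing measured here explains why the two arrangements differ.

From the compounds shown here alone, it remains open whether this sensitivity belongs to the methoxy group alone or would also appear with a hydroxyl group, a chlorine atom, an amine or a longer chain such as ethoxy on the same phenyl ring. Also open, going by these compounds, is whether a group without a phenyl ring at this carbon, such as a carboxylic acid or a short alkyl chain, would stand clearly apart from hydrogen.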